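Cytotoxicity notes: 2-hydroxyethyl for cyclohexyl on compound 1

This account rests on a few compounds, and the source may have more. Where it says the series, first, only, none or still open, it means among the compounds named here.

Compound 1 `FC(F)(F)Oc1ccc(Nc2ncnc3c2cnn3C2CCCCC2)cc1`: 9300 nM in an ADME assay on BaF3 cells (Mus musculus) for cytotoxicity; on this read-out lower numbers stand for an effect already at smaller amounts and higher numbers for an effect only at larger amounts of compound.
Compound 2 `FC(F)(F)c1ccc(Nc2cc(-c3ccncc3)ncn2)cc1`: only the assay limit, > 10000 nM.
Compound 3 `NC(=O)c1ccc(-c2cc(Nc3ccc(OC(F)(F)F)cc3)ncn2)cc1`: again only the assay limit, > 10000 nM.

Among the compounds with values here, compound 1 holds the only numeric value in this assay; the other two entries are limits, (the limit of > 10000 nM in this assay, at which 2 of the 3 values shown sit). Within the data shown here, no step between measured compounds exists, so the change to compound 4 `OCCn1ncc2c(Nc3ccc(OC(F)(F)F)cc3)ncnc21` is followed directly: 2-hydroxyethyl in place of cyclohexyl on an aromatic nitrogen. Among the measured compounds shown here, with no measured step to lean on, a step within the scatter or toward an effect only at larger amounts is expected, since compound 1 itself already shows an effect only at larger amounts, at 9300 nM. Compound 4 is expected at 15000 nM, range 5000 nM to 40000 nM. The expected step of a 1.6-fold higher number from compound 1 to compound 4 (0.21 log units; within the scatter) is small and may well end as a limit.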

Compound 4, half-maximal effective concentration: > 10000 nM
Compound 4: only a limit was reported; the forecaster's own chance of this, stated with the estimate: 65%; the middle value is on the limit's open side.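

In this assay, compound 4 is reported only as a limit, > 10000 nM. Within the data shown here, this gives the first reading at this position: 2-hydroxyethyl in place of cyclohexyl on an aromatic nitrogen yields an at least 1.0-fold higher number from compound 1 to compound 4 (0.03 log units; that floor lies within the scatter), a step with a floor but no measured size. Compound 1 keeps the only numeric value, and compound 4 joins the entries at the limit: the limit of > 10000 nM in this assay, at which 3 of the 4 values shown sit.

As far as these compounds go, it remains open how far the true value of compound 4 lies from that limit. Also open, from the compounds shown here alone, is whether an amine, a carboxylic acid or a longer chain on the same aromatic nitrogen would give a numeric value in this assay.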